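Amide side chain variation at the cytotoxicity limit

The source may hold more compounds than are shown below. What is called first, only, known or untested is meant among the compounds shown, and "the series" means these compounds.

Working notes on the series varied at the amide-type nitrogen of the shared core.

Compound 1 `O=C(Nc1ccc(F)cc1)c1c(NO)cc(-c2ccccc2)oc1=O` carries a 4-fluorophenyl on the amide-type nitrogen. In an ADME assay on Huh-7 cells (Homo sapiens) for cytotoxicity, read by a luciferase reporter and WST assay, with a stated time of 3 days (on this read-out lower numbers stand for higher toxicity in this test and higher numbers for lower toxicity in this test), compound 1 gives > 20000 nM, which is a limit of the assay and not a number. Compound 2 `O=C(NCCCO)c1c(NO)cc(-c2ccccc2)oc1=O` carries a 3-hydroxypropyl in its place. In this assay compound 2 gives > 20000 nM, again a limit and not a number. The step that the two limits leave unreadable from compound 1 to compound 2 cannot be read because both values sit at the limit of > 20000 nM in this assay, at which 2 of the 2 values shown sit. Within the data shown here, compound 2 thus stands at the limit, and the one further value shown is a limit as well.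

Compound 3 `COC(=O)CNC(=O)c1c(NO)cc(-c2ccccc2)oc1=O` differs from compound 2 by methoxycarbonyl in place of 2-hydroxyethyl on a saturated chain carbon bound to an amide-type nitrogen. Among the measured compounds shown here, the only measured step that bears on the amide substituent is a step that the two limits leave unreadable from compound 1 to compound 2, and its size is not readable. No direction can be taken from the two values shown. In this assay compound 3 is therefore expected to show a step that the limit leaves unreadable from compound 2 to compound 3. The estimate for compound 3 is 30000 nM, with a range from 10000 nM to 100000 nM, most likely reported as another limit.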

Compound 3, half-maximal cytotoxic concentration: > 20000 nM
Compound 3: a limit, no number; the forecaster's own chance of this, stated with the estimate: 85%; the middle value does not contradict the limit.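

In this assay compound 3 gives > 20000 nM, a limit of the assay and not a number. No new step can therefore be read from compound 1 or compound 2 to compound 3, all three values sitting at one limit: the limit of > 20000 nM in this assay, at which 3 of the 3 values shown sit.

The compounds shown leave open whether any amide side chain on the shared core gives a measurable half-maximal cytotoxic concentration in this assay.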